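Swapping a Cyclohexyl for an Aminophenyl on the Side Chain

This account rests on a few compounds, and the source may have more. Where it says the series, first, only, none or still open, it means among the compounds named here.

Of the compounds shown here, two sharing one core have been measured in an assay on cell membranes for binding affinity to adenosine receptor A1 (Bos taurus), read by radioligand binding; a lower number here means a stronger inhibitor, a higher number a weaker inhibitor. Compound 1, `c1ccc(Cn2nnc3c(NCC4CCCCC4)ncnc32)cc1`, gives 2790 nM, the lower of the two numbers. Compound 2, `Clc1ccccc1Cn1nnc2c(NCC3CCCCC3)ncnc21`, carries a chloro in place of hydrogen on an aromatic carbon and gives 4260 nM; the step of a 1.5-fold higher number from compound 1 to compound 2 (0.18 log units; within the scatter) stays within the scatter, so the two look alike.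

Compound 3, `Nc1ccc(CNc2ncnc3c2nnn3Cc2ccccc2)cc1`, is not yet measured. It differs from compound 1 in one place: 4-aminophenyl in place of cyclohexyl on a saturated chain carbon bound to a nitrogen on an aromatic ring. Going by the values given here, no measured step touches this part of the molecule, since the only step available concerns the chloro on the other ring and was itself within the scatter. The expectation for compound 3 therefore rests on the change alone, and the exchange of a saturated ring for an aminophenyl is expected to give a somewhat higher number, a 2.9-fold higher number from compound 1 to compound 3 (0.46 log units; beyond the scatter). Compound 3 is accordingly estimated at 8000 nM, with a range from 2000 nM to 30000 nM.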

Compound 3, inhibition constant: 9500 nM
Estimate against measurement, compound 3: 1.2-fold (0.07 log units) below; the range from low to high includes it.
By their numbers in this assay, from the lowest: compounds 1 and 2 (each within the scatter of the next); then compound 3.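

In this assay, the side chain responds more clearly than the other ring did: 4-aminophenyl in place of cyclohexyl gives a 3.4-fold higher number from compound 1 to compound 3 (0.53 log units; beyond the scatter). Unlike the chloro step, this change lies beyond the scatter, so the group on this saturated chain carbon does affect the number, and here the aromatic amine-bearing ring gives the weaker binder. Nothing available explains the rise.

On these data alone, this single step replaces the saturated ring with an aromatic one and adds the amine at the same time, so the contribution of each remains unknown. A plain phenyl at this place would separate the two, while a hydroxyl in place of the amine, or a longer chain leading to the ring, would show how far the trend extends.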